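Lengthening the Chain from Compound 3 to Compound 4

This account rests on a few compounds, and the source may have more. Where it says the series, first, only, none or still open, it means among the compounds named here.

Of the compounds shown here, three have so far been measured in an ADME assay on BEAS-2B cells (Homo sapiens) for cytotoxicity, read by MTT assay, with a stated time of 72 h; on this read-out lower numbers stand for stronger inhibition of growth and higher numbers for weaker inhibition of growth. Compound 1 `COc1ccc(OC(=O)Nc2ccc([Se]C#N)cc2)cc1` gives 25200 nM, compound 2 `CC(C)COC(=O)Nc1ccc([Se][Se]c2ccc(NC(=O)OCC(C)C)cc2)cc1` gives 13100 nM, and compound 3 `CCCCOC(=O)Nc1ccc([Se]C#N)cc1` gives 5000 nM. Compound 3 thus stands at the lowest of the three numbers; its nearest neighbour is compound 2, whose number lies higher by a margin beyond the scatter, and the furthest is compound 1, also beyond the scatter. No two of these compounds differ in only one place, so no step between measured compounds is available.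

Compound 4 `CCCCCCOC(=O)Nc1ccc([Se]C#N)cc1` has not yet been measured in this assay. It differs from compound 3 in a single place: ethyl in place of hydrogen on a saturated chain carbon, four bonds along the chain from an oxygen next to a carbonyl group. Within the data shown here, nothing among the measured compounds shows what lengthening this saturated chain does, since compound 1 and compound 2 differ from compound 3 in more than that. The expected step is therefore modest, most likely within the scatter, with a slight lean toward a lower number, and is estimated as a 1.4-fold lower number from compound 3 to compound 4 (0.15 log units; within the scatter). Compound 4 is accordingly expected to give about 3500 nM, within an estimated range from 1500 nM to 9000 nM.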

Compound 4, concentration for 50% growth inhibition: 2800 nM
Compound 4: middle estimate off by 1.3-fold (0.10 log units), on the high side; the range from low to high includes it.
By their numbers in this assay, from the lowest: compounds 4 and 3 (each within the scatter of the next); then compounds 2 and 1 (each within the scatter of the next).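

In this assay, the position on the saturated chain now has its first readable step, a 1.8-fold lower number from compound 3 to compound 4 (0.25 log units; within the scatter), for ethyl in place of hydrogen four bonds along the chain from an oxygen next to a carbonyl group. Compound 1 and compound 2 differ from compound 3 in more than that one place, so they could not show what this change does; the new pair shows that adding these 2 carbon atoms, with no ring, donor, acceptor or charge, leaves the two numbers within the scatter of each other. No available measurement explains the size of this step.

A single step cannot show how the read-out would respond at this position to a longer chain, or to a chain ending in an amine or a carboxylic acid. It also leaves open whether the same change would give a step of similar size on the core of compound 1 or compound 2, or whether any change at this position can give a step beyond the scatter.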